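This account rests on a few compounds, and the source may have more. Where it says the series, first, only, none or still open, it means among the compounds named here.

Three compounds that share one core were tested in an ADME assay on HEK293 cells (Homo sapiens) for cytotoxicity, read by ATP content, with a stated time of 6 h; a higher number here means that more compound is tolerated, a lower number that less compound is tolerated. Compound 1 `CCCCNc1nc(N)nc2ccn(Cc3cccc(C)n3)c12` gives > 24000 nM in this assay, a limit of the assay rather than a number. Compound 2 `CCCCNc1nc(N)nc2ccn(Cc3ncc(C)c(OC)c3C)c12` gives > 24000 nM in this assay, again only a limit. Compound 3 `COCCCNc1nc(N)nc2ccn(Cc3ccccn3)c12` gives > 24000 nM in this assay, also a limit and not a measured number. Compound 3 thus stands at the limit of > 24000 nM in this assay, at which 3 of the 3 values shown sit, with no number of its own to set it apart from compound 1 or compound 2.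

Compound 4 `Nc1nc(NCc2ccon2)c2c(ccn2Cc2ccccn2)n1` has not yet been measured. It differs from compound 3 in one place: 1,2-oxazol-3-yl in place of 2-methoxyethyl on a saturated chain carbon bound to a nitrogen on an aromatic ring. For the measured compounds named here, no pair of measured compounds differs in a comparable way, and nothing measured speaks to this exchange.

Compound 3 sits at the limit of > 24000 nM in this assay, at which 3 of the 3 values shown sit, as do compound 1 and compound 2. The step from compound 3 to compound 4 is expected to be a step that the limit leaves unreadable from compound 3 to compound 4, none beyond the scatter. Compound 4 is therefore estimated at 30000 nM in this assay, within 15000 nM to 60000 nM, most likely reported as a further limit.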

Compound 4, half-maximal cytotoxic concentration: > 24000 nM
Compound 4 gave a limit, no number; the forecaster's own chance of this, stated with the estimate: 85%; the middle value is on the limit's open side.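

No step can be read between compound 3 and compound 4, because in this assay both give only a limit, not a number: the limit of > 24000 nM in this assay, at which 4 of the 4 values shown sit.

The compounds shown leave open where the true half-maximal cytotoxic concentration of any of the four lies, and so whether 1,2-oxazol-3-yl in place of 2-methoxyethyl makes any difference.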